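This account rests on a few compounds, and the source may have more. Where it says the series, first, only, none or still open, it means among the compounds named here.

Compound 2 `COc1ccc(OC)c(-n2nncc2CN2C(=O)C3(C(C#N)=C(N)Oc4c(N)cc5nc6ccccc6nc5c43)c3ccccc32)c1` gives the higher of the two numbers recorded in a functional assay on HepG2 cells (Homo sapiens) for antiproliferative activity, read by MTT assay, with a stated time of 48 h (a lower number here means a stronger inhibitor, a higher number a weaker inhibitor), namely 45100 nM. Its nearest neighbour is compound 1 `CCOc1ccccc1-n1nncc1CN1C(=O)C2(C(C#N)=C(N)Oc3c(N)cc4nc5ccccc5nc4c32)c2ccccc21`, which in this assay gives 30500 nM; the step of a 1.5-fold higher number from compound 1 to compound 2 (0.17 log units; within the scatter) lies within the scatter, so the two compounds cannot be ordered on these numbers. Compound 3 `Cc1ccc(Cl)cc1-n1nncc1CN1C(=O)C2(C(C#N)=C(N)Oc3c(N)cc4nc5ccccc5nc4c32)c2ccccc21` carries 5-chloro-2-methylphenyl in place of 2,5-dimethoxyphenyl on an aromatic nitrogen on the shared core. Going by the values given here, the only measured step that bears on this change is a 1.5-fold higher number from compound 1 to compound 2 (0.17 log units; within the scatter), in which one alkoxy-bearing phenyl group was exchanged for another without a shift beyond the scatter. Among the compounds with values here, no measured step shows what removing both hydrogen-bond acceptors from this phenyl group and bringing in a chlorine does. On that basis the step of a 1.3-fold lower number from compound 2 to compound 3 (0.11 log units; within the scatter) is expected to be small, with no direction claimed beyond the scatter. Compound 3 is therefore estimated in this assay at 35000 nM, within the range from 12000 nM to 100000 nM.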

Compound 3, half-maximal inhibitory concentration: 17300 nM
Estimate against measurement, compound 3: 2.0-fold (0.31 log units) above; the range from low to high includes it.
By their numbers in this assay, from the lowest: compounds 3, 1 and 2 (each within the scatter of the next, the first and the last beyond it).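

In this assay, the group on the aromatic nitrogen now gives a step beyond the scatter, with a 2.6-fold lower number from compound 2 to compound 3 (0.42 log units; beyond the scatter) as the only such step at this position among the compounds shown, and a modest one. The change replaces 2,5-dimethoxyphenyl, with 2 hydrogen-bond acceptors, by 5-chloro-2-methylphenyl, with 0 hydrogen-bond acceptors, yet the other new step, a 1.8-fold lower number from compound 1 to compound 3 (0.25 log units; within the scatter), stays within the scatter, so compound 3 cannot be ordered against compound 1. No measurement here explains the shift.

Because the chlorine and the methyl enter together while both methoxy groups leave, the compounds shown do not separate the contribution of any single group. As far as these compounds go, it also remains open how this position would respond to a plain phenyl group or to a phenyl ring carrying an amine or a carboxylic acid.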